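This account rests on a few compounds, and the source may have more. Where it says the series, first, only, none or still open, it means among the compounds named here.

Among the compounds with values here, compound 2 `CNC1=CC(=O)c2cc(C)ncc2C1=O` gives the lower of the two numbers measured so far in a functional assay on cells (Homo sapiens) for cytotoxicity, read by propidium iodide staining, with a stated time of 4 days; on this read-out lower numbers stand for stronger inhibition and higher numbers for weaker inhibition: compound 2 gives 3600 nM. Within the data shown here, the only other measured compound is compound 1 `CNC1=CC(=O)c2c(cnc(C)c2C)C1=O`, which gives 31900 nM, and the step of an 8.9-fold lower number from compound 1 to compound 2 (0.95 log units; beyond the scatter) is the sole measured step, a hydrogen in place of methyl on an aromatic carbon. Compound 3 `Cc1cc2c(cn1)C(=O)C(NCl)=CC2=O` is reached from compound 2 by a different kind of change, (chloro in place of methyl on an amine nitrogen). Among the measured compounds shown here, no measured step concerns this amine nitrogen or a chloro group, so the step from compound 1 to compound 2 does not bear on it; it only shows that a single-atom change on this core can move the number well beyond the scatter. For the measured compounds named here, with no guiding step, compound 3 is expected to land close to compound 2, no change at the digits printed from compound 2 to compound 3 (within the scatter), with wide uncertainty. The estimate for compound 3 is 3600 nM, ranging from 900 nM to 14000 nM.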

Compound 3, half-maximal inhibitory concentration: 1750 nM
The estimate for compound 3 lay 2.1-fold (0.31 log units) above the measured number; measured number inside the range.
By their numbers in this assay, from the lowest: compound 3; then compound 2; then compound 1.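

In this assay, the amine nitrogen proves to be a second place on the shared core where a single-group change moves the number beyond the scatter: chloro in place of methyl gives a 2.1-fold lower number from compound 2 to compound 3 (0.31 log units; beyond the scatter). Within the data shown here, the earlier step concerned only an aromatic carbon, so this is the first sign that the group on this nitrogen matters, and the change lowers the number rather than raising it, although only modestly. Nothing available here explains why the number moves with this change.

The compounds shown leave open how other groups on this amine nitrogen, such as ethyl, a longer chain or an acetyl group, would compare with methyl and chloro. They also leave open whether the chloro change would give a step of similar size on the core of compound 1.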